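Branching the Unsaturated Amide Chain: A Second Extension

A few compounds are considered here, and "the series" means these few. Any claim that something is new, unique, unknown or untested is made for them only; others in the source may bear on it.

Measured so far:
compound 1, `C=CC(=O)Nc1cccc(Oc2nc(Nc3cccc(OC)c3)nc3ccsc23)c1`, 4790 nM
compound 2, `CC/C=C/C(=O)Nc1cccc(Oc2nc(Nc3cccc(OC)c3)nc3ccsc23)c1`, 29200 nM

In a functional assay on A-431 cells (Homo sapiens) for inhibition, read by MTT assay, with a stated time of 72 h (a lower number here means a stronger inhibitor, a higher number a weaker inhibitor), compound 2 gives the higher of the two numbers; the step of a 6.1-fold higher number from compound 1 to compound 2 (0.79 log units; beyond the scatter) was beyond the scatter. Compound 3, `COc1cccc(Nc2nc(Oc3cccc(NC(=O)/C=C/C(C)C)c3)c3sccc3n2)c1`, differs from compound 2 by methyl in place of hydrogen on a saturated chain carbon bound to a double-bonded chain carbon and a saturated chain carbon. Within the data shown here, only that one step bears on it, and it pointed toward weaker inhibition as the chain grew; a further methyl is expected to push the same way, though perhaps less. The estimated step is a 1.7-fold higher number from compound 2 to compound 3 (0.23 log units; within the scatter). Compound 3 is therefore expected at 50000 nM, with a range of 18000 nM to 140000 nM.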

Compound 3, half-maximal inhibitory concentration: 23400 nM
For compound 3 the middle estimate is 2.1-fold (0.33 log units) above the measured one; low and high end bracket the measured number.
By their numbers in this assay, from the lowest: compound 1; then compounds 3 and 2 (each within the scatter of the next).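

Placing a methyl on the saturated chain carbon bound to a double-bonded chain carbon makes no clear difference in this assay, with a 1.2-fold lower number from compound 2 to compound 3 (0.10 log units; within the scatter) within the scatter, so the ethyl and isopropyl chain ends cannot be told apart here. Replacing vinyl with 3-methylbut-1-en-1-yl still gives weaker inhibition, with a 4.9-fold higher number from compound 1 to compound 3 (0.69 log units; beyond the scatter) beyond the scatter. Nothing measured here explains these numbers.

Still open, going by these compounds, is how this chain would behave if it ended in an amine, such as dimethylamino, or in a carboxylic acid rather than a branched carbon chain.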